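Chloro added to the phenyl of compound 3

The compounds below may be only part of what the source reports. "The series", "measured", "known", "first", "only" and "open" are said of these compounds alone.

Values in a functional assay on MOLT-4 cells (Homo sapiens) for inhibition; on this read-out lower numbers stand for stronger inhibition of growth and higher numbers for weaker inhibition of growth:
compound 1 `Cc1cc(S(=O)(=O)Nc2nc3cscc3c(=O)n2Cc2ccccc2)c(S)cc1Cl`: 3900 nM
compound 2 `Cc1cc(S(=O)(=O)Nc2nc3ccsc3c(=O)n2Cc2ccco2)c(S)cc1Cl`: 19400 nM
compound 3 `Cc1cc(S(=O)(=O)Nc2nc3cc(-c4ccccc4)sc3c(=O)n2Cc2ccccc2)c(S)cc1Cl`: > 100000 nM

Compound 3 reports only a limit of the assay, > 100000 nM, and no number (the limit of > 100000 nM in this assay, at which 1 of the 3 values shown sits). Compound 1 at 3900 nM and compound 2 at 19400 nM give numbers, whereas compound 3 stands at the weak end of the series, beyond the range the assay resolves.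

Compound 4, `Cc1cc(S(=O)(=O)Nc2nc3cc(-c4ccc(Cl)cc4)sc3c(=O)n2Cc2ccccc2)c(S)cc1Cl`, differs from compound 3 by chloro in place of hydrogen on an aromatic carbon. For the measured compounds named here, no step between measured compounds bears on this change, so no shift beyond the scatter is expected; the expected step is a step that the limit leaves unreadable from compound 3 to compound 4. For compound 4 the estimate is 150000 nM, within 40000 nM to 600000 nM, most probably again only a limit.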

Compound 4, concentration for 50% growth inhibition: > 100000 nM
Compound 4 gave a limit, no number; the forecaster's own chance of this, stated with the estimate: 80%; the middle value does not contradict the limit.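

In this assay compound 3 and compound 4 each give only a limit, so no step can be read between them: the limit of > 100000 nM in this assay, at which 2 of the 4 values shown sit. The compounds shown leave open whether going from phenyl to 4-chlorophenyl changes growth inhibition at all.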